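Trading a dimethylamino for an acetyl on the outer phenyl

This account rests on a few compounds, and the source may have more. Where it says the series, first, only, none or still open, it means among the compounds named here.

Among the measured compounds shown here, the series shares one core, and compound 1 `COc1cc(C)cc(-c2c(-c3ccnc(-c4ccc(N(C)C)cc4)c3)cnn2CC#N)c1` is the only member with a full number. In a functional assay on NCI-H522 cells (Homo sapiens) for inhibition, read by sulforhodamine B assay, with a stated time of 48 h (a lower number here means that less compound is tolerated, a higher number that more compound is tolerated), compound 1 gives 3220 nM. Compound 2 `COc1cc(C)cc(-c2nn(CC#N)cc2-c2ccc(-c3cccc(C(C)=O)c3)nc2)c1` is recorded only as a limit, > 100000 nM, in this assay. For the measured compounds named here, that limit is the only evidence beside compound 1: the limit of > 100000 nM in this assay, at which 1 of the 2 values shown sits.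

Compound 3 `COc1cc(C)cc(-c2c(-c3ccnc(-c4ccc(C(C)=O)cc4)c3)cnn2CC#N)c1` keeps the whole of compound 1 except for one change, (acetyl in place of dimethylamino on an aromatic carbon). Going by the values given here, no measured pair shows this exact move, so the step from compound 1 to compound 3 is expected rather than known. Among the compounds with values here, the only other acetyl-bearing compound, compound 2, gives only the limit > 100000 nM, which points toward a loss of cell kill when the acetyl enters. For compound 3 the estimate is 20000 nM, within 5000 nM and 100000 nM, so that the expected step in this assay is a 6.2-fold higher number from compound 1 to compound 3 (0.79 log units; beyond the scatter).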

Compound 3, concentration lethal to 50% of the cells: > 100000 nM
Compound 3: no number, only a limit; the forecaster's own chance of this, stated with the estimate: 35%; middle value at least 5.0-fold (0.69 log units) from the limit.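

Among the compounds shown here, with compound 3, the change from 4-(dimethylamino)phenyl to 4-acetylphenyl can be read for the first time as a single step on the shared core: it gives an at least 31-fold higher number from compound 1 to compound 3 (1.49 log units; beyond the scatter) in this assay on this position, para to a large group. The value of compound 3 is a limit and not a number, so the step carries that limit with it. Of the compounds shown, only the one with dimethylamino at this position gives a full number, and the acetyl compound joins compound 2 at the limit: the limit of > 100000 nM in this assay, at which 2 of the 3 values shown sit.

One pair cannot tell whether the step comes from the loss of dimethylamino or from the entry of acetyl. Going by these compounds, what a primary amine, a methoxy group or a carboxylic acid would give at this position stays open.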